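The compounds below may be only part of what the source reports. "The series", "measured", "known", "first", "only" and "open" are said of these compounds alone.

In a functional assay on Jurkat cells (Homo sapiens) for cytotoxicity, read by luminescence and CellTiter-Glo, with a stated time of 3 days (on this read-out higher numbers stand for weaker inhibition and lower numbers for stronger inhibition), compound 1 (`O=C(Nc1cc(C(F)(F)F)cc(C(F)(F)F)c1)c1ccc(Br)cc1O`) gives 930 nM, compound 2 (`O=C(Nc1cc(C(F)(F)F)cc(C(F)(F)F)c1)c1cc(F)ccc1O`) gives 500 nM and compound 3 (`O=C(Nc1cc(C(F)(F)F)cc(C(F)(F)F)c1)c1ccc(Cl)cc1O`) gives 570 nM, so compound 3 stands within the scatter of both others. Compound 4 (`O=C(Nc1cc(C(F)(F)F)cc(C(F)(F)F)c1)c1cc(Br)ccc1O`) carries 5-bromo-2-hydroxyphenyl in place of 4-chloro-2-hydroxyphenyl on a carbonyl carbon. Among the compounds with values here, three measured steps bear on this change. Chloro in place of bromo gives a 1.6-fold lower number from compound 1 to compound 3 (0.21 log units; within the scatter). The exchanges of the substituted 2-hydroxyphenyl groups give a 1.9-fold lower number from compound 1 to compound 2 (0.27 log units; within the scatter) and a 1.1-fold higher number from compound 2 to compound 3 (0.06 log units; within the scatter). All three stay within the scatter, so no step beyond the scatter is expected in this assay, and no firm direction. The expected step is a 1.1-fold higher number from compound 3 to compound 4 (0.06 log units; within the scatter). Compound 4 is estimated at 650 nM, with an expected range of 300 nM to 1400 nM.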

Compound 4, half-maximal inhibitory concentration: 350 nM
Compound 4: middle estimate off by 1.9-fold (0.27 log units), on the high side, within the range that was stated.
By their numbers in this assay, from the lowest: compounds 4, 2, 3 and 1 (each within the scatter of the next, the first and the last beyond it).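

In this assay, 5-bromo-2-hydroxyphenyl in place of 4-bromo-2-hydroxyphenyl on the carbonyl carbon gives a 2.7-fold lower number from compound 1 to compound 4 (0.42 log units; beyond the scatter), a modest step and the only one in the series beyond the scatter, so these two bromo-bearing groups are not interchangeable. Bromo in place of fluoro gives a 1.4-fold lower number from compound 2 to compound 4 (0.15 log units; within the scatter) and the exchange for 4-chloro-2-hydroxyphenyl gives a 1.6-fold lower number from compound 3 to compound 4 (0.21 log units; within the scatter), both within the scatter. No available measurement explains the step between the two bromo-bearing groups.

Going by these compounds, whether that step carries over to chloro or fluoro stays open. So does the effect of an amine, a nitrile or a carboxylic acid in place of the halogen.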